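The source may hold more compounds than are shown below. What is called first, only, known or untested is meant among the compounds shown, and "the series" means these compounds.

Measured in a functional assay on the whole organism for inhibition, with Rattus norvegicus as the target, read by paw edema, with stated times of 1 h and 3 h; a lower number here means that less compound is needed, a higher number that more compound is needed for the effect:
Compound 1 `C/C(=N\OCC(=O)OC(C)C)c1ccc(Cl)cc1`: 50 mg/kg
Compound 2 `C/C(=N\OCC(=O)N(C)C)c1ccc(Cl)cc1`: 120 mg/kg

Of these two, compound 2 has the higher number, so it needs more compound for the effect. Within the data shown here, the gap is the one measured step, a 2.4-fold higher number from compound 1 to compound 2 (0.38 log units; beyond the scatter).

The next compound is compound 3 `C/C(=N\OCCO)c1ccc(Cl)cc1`, which has hydroxymethyl in place of dimethylcarbamoyl on a saturated chain carbon bound to an oxygen. The measured step bears on this change only loosely. It put dimethylamino in place of isopropoxy on a carbonyl carbon, whereas here the carbonyl carbon itself leaves. Both measured compounds keep that carbonyl, so the data give no direction for its loss. Among the measured compounds shown here, with a 2.4-fold higher number from compound 1 to compound 2 (0.38 log units; beyond the scatter) as the only guide to size, a modest step at most is expected in this assay, and none beyond the scatter is the likeliest outcome. The expected change is a 1.2-fold lower number from compound 2 to compound 3 (0.08 log units; within the scatter). For compound 3 the estimate is 100 mg/kg, with an expected range from 40 mg/kg to 250 mg/kg.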

Compound 3, dose for half-maximal effect: 29 mg/kg
Estimate against measurement, compound 3: 3.4-fold (0.54 log units) above; the measured number lies below the stated range.
By their numbers in this assay, from the lowest: compounds 3 and 1 (each within the scatter of the next); then compound 2.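

Taking the carbonyl away from this saturated chain carbon bound to an oxygen did not raise the dose in this assay, as the earlier compounds, which both keep that carbonyl, could not show: hydroxymethyl in place of dimethylcarbamoyl gives a 4.1-fold lower number from compound 2 to compound 3 (0.62 log units; beyond the scatter) and so reverses the direction of the only earlier step, which had gone up on moving from the ester to the amide. Hydroxymethyl in place of isopropoxycarbonyl gives a 1.7-fold lower number from compound 1 to compound 3 (0.24 log units; within the scatter) and so leaves compound 3 and compound 1 unordered, which means that the smaller hydroxymethyl group matches the ester and stands clear only of the amide. Within these three compounds, then, a carbonyl at this place is not needed for the effect in this assay, and the dimethylcarbamoyl of compound 2 is the one group of the three that goes against an otherwise level picture.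

The compounds shown leave open how a carboxylic acid, an amine or a longer chain ending in hydroxyl would read on this same saturated chain carbon. No measurement is available that explains why the amide stands apart from the other two compounds.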